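Swapping the Benzyl Arm for an Ester-Bearing Chain

The source may report more compounds than this note shows. Statements on the series, on what has been measured and on what is new or still open speak of the compounds shown alone.

Measured compounds:
compound 1, `Cc1ccc(CNC(=O)c2[nH]cnc2C(=O)Nc2ccc(Cl)c(Cl)c2)cc1`: 21400 nM
compound 2, `C[C@H](NC(=O)c1[nH]cnc1C(=O)Nc1ccc(Cl)c(Cl)c1)C(=O)OC(C)(C)C`: 4900 nM
compound 3, `COC(=O)[C@H](NC(=O)c1[nH]cnc1C(=O)Nc1ccc(Cl)c(Cl)c1)c1ccccc1`: 17300 nM

All three share one core and differ only in the group carried on an amide-type nitrogen. In a functional assay on HL-60 cells (Homo sapiens), with a stated time of 2 days (on this read-out higher numbers stand for weaker inhibition and lower numbers for stronger inhibition), compound 1 gives the highest of the three numbers, so it is the weakest inhibitor seen here; compound 3 sits within the scatter of it, while compound 2 lies clearly lower.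

The unmeasured compound 4, `COC(=O)[C@H](NC(=O)c1[nH]cnc1C(=O)Nc1ccc(Cl)c(Cl)c1)C(C)C`, is reached from compound 1 by the change (1-(methoxycarbonyl)-2-methylpropyl in place of 4-methylbenzyl on an amide-type nitrogen). Among the measured compounds shown here, only one measured step bears on this: a 4.4-fold lower number from compound 1 to compound 2 (0.64 log units; beyond the scatter), where an ester-bearing chain likewise replaced the 4-methylbenzyl group. Compound 3, with its methyl ester carrying a phenyl group, shows that not every ester-bearing chain brings the number down far. Compound 4 carries a methyl ester like compound 3 but a small branched chain like compound 2, so a lower number than compound 1 is expected, of a size between those two cases.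

For compound 4 the estimate is 7500 nM, with a range from 2500 nM to 20000 nM, which is expected to mean a step of a 2.9-fold lower number from compound 1 to compound 4 (0.46 log units; beyond the scatter).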

Compound 4, half-maximal inhibitory concentration: 8500 nM
Compound 4: middle estimate off by 1.1-fold (0.05 log units), on the low side; low and high end bracket the measured number.
By their numbers in this assay, from the lowest: compounds 2 and 4 (each within the scatter of the next); then compounds 3 and 1 (each within the scatter of the next).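

A second ester-bearing chain without a ring also improves on the 4-methylbenzyl group in this assay, with a 2.5-fold lower number from compound 1 to compound 4 (0.40 log units; beyond the scatter), so compound 2 is no longer the only such case, although compound 3 goes against this pattern by staying within the scatter of compound 1. The methyl ester alone therefore does not settle the outcome: with that ester held constant, isopropyl in place of phenyl on the saturated chain carbon gives a 2.0-fold lower number from compound 3 to compound 4 (0.31 log units; beyond the scatter), which shows that the group on this carbon matters. The two ring-free ester chains cannot be told apart, as a 1.7-fold higher number from compound 2 to compound 4 (0.24 log units; within the scatter) lies within the scatter, so the change from 1-(tert-butoxycarbonyl)ethyl to 1-(methoxycarbonyl)-2-methylpropyl shows no clear effect on this read-out.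

No supporting data explain why the isopropyl chain gives a lower number than the phenyl chain. On these data alone, it remains open how a carboxylic acid in place of the ester, or an amine or a longer chain on the same carbon, would compare.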